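The compounds below may be only part of what the source reports. "The series", "measured", "known", "first", "only" and "open" are said of these compounds alone.

Measured in a functional assay on RS4-11 cells (Homo sapiens) for inhibition, read by CCK-8 assay, with a stated time of 48 h, tested at 20 uM; a lower number here means less inhibition of growth, a higher number more inhibition of growth at the concentration tested:
- compound 1 `N#C/C(=C\c1ccccc1OS(=O)(=O)c1ccc([N+](=O)[O-])cc1)C(=O)Nc1nnc(Cc2cccc3ccccc23)s1` gives 58%
- compound 2 `N#C/C(=C\c1ccccc1OS(=O)(=O)c1ccc([N+](=O)[O-])cc1)C(=O)Nc1nnc(Cc2ccccc2)s1` gives 57%
- compound 3 `Cc1ccc(S(=O)(=O)Oc2ccccc2/C=C(\C#N)C(=O)Nc2nnc(Cc3ccc(Cl)cc3)s2)cc1` gives 69%

Compound 3 stands highest of the three, and its gap to each of the others lies beyond the scatter. Compound 4 `N#C/C(=C\c1ccccc1OS(=O)(=O)c1ccc([N+](=O)[O-])cc1)C(=O)Nc1nnc(Cc2ccc(Cl)cc2)s1` has nitro in place of methyl on an aromatic carbon, para to a large group (nitro in place of methyl on an aromatic carbon). Among the measured compounds shown here, no measured step covers this change directly. For the measured compounds named here, the one measured step, a number 1 percentage points lower from compound 1 to compound 2 (within the scatter), concerns phenyl in place of naphthalen-1-yl, a change elsewhere in the molecule, so it bears only indirectly. It suggests that this other region matters little here. Compound 1 at 58% and compound 2 at 57% already carry the (4-nitrophenyl)sulfonyl group of compound 4, though both also differ from it elsewhere. A modest fall from compound 3 is therefore expected, not a full drop to their level. The estimated change is a number 7 percentage points lower from compound 3 to compound 4 (within the scatter), which may not clearly exceed the scatter. For compound 4 the expected value is 62%, with an estimated range from 50% to 74%.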

Compound 4, percent growth inhibition at one concentration: 66%
The estimate for compound 4 lay 4 percentage points below the measured number, within the range that was stated.
By their numbers in this assay, from the lowest: compounds 2, 1, 4 and 3 (each within the scatter of the next, the first and the last beyond it).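

Exchanging (4-methylphenyl)sulfonyl for (4-nitrophenyl)sulfonyl in this assay gives a number 3 percentage points lower from compound 3 to compound 4 (within the scatter) and so shows no effect that can be told apart from the scatter at this position. With (4-nitrophenyl)sulfonyl held fixed, the steps on the other side of the molecule stay within the scatter as well, with chloro in place of hydrogen on an aromatic carbon giving a number 9 percentage points higher from compound 2 to compound 4 (within the scatter) and 4-chlorophenyl in place of naphthalen-1-yl giving a number 8 percentage points higher from compound 1 to compound 4 (within the scatter) in this set. No supporting data are available to explain any of these results.

The compounds shown leave open whether an amine or a methoxy group on this same aromatic carbon would also stay within the scatter of methyl and nitro. They also leave open how a carboxylic acid there would read at the single concentration tested.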